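The compounds below may be only part of what the source reports. "The series", "measured", "known", "first", "only" and "open" are said of these compounds alone.

Compound 2, `CS(=O)(=O)Nc1ccc2c(c1)S(=O)(=O)N=C(C1=C(O)C3CCCC3N(Cc3ccc(F)cn3)C1=O)N2`, belongs to a small set sharing one core. Its companions are compound 1, `CC(C)(C)CCN1C(=O)C(C2=NS(=O)(=O)c3cc(NS(C)(=O)=O)ccc3N2)=C(O)C2CCCCCCC21`, and compound 3, `CS(=O)(=O)Nc1ccc2c(c1)S(=O)(=O)N=C(C1=C(O)C3CCCCCCC3N(Cc3ccc(F)cc3)C1=O)N2`. In an ADME assay on Huh-7 cells (Homo sapiens) for cytotoxicity, with a stated time of 72 h (a lower number here means that less compound is tolerated, a higher number that more compound is tolerated), compound 2 gives only a limit of the assay, > 33000 nM. Compound 3 likewise reaches only a limit in this assay, > 33000 nM. For compound 1 the entry in this assay reads "not determined" (no result reported). Thus compound 2 stands where every numbered value shown stands, at the limit of > 33000 nM in this assay, at which 2 of the 3 values shown sit, with no step between measured compounds to lean on. Compound 4, `CS(=O)(=O)Nc1ccc2c(c1)S(=O)(=O)N=C(C1=C(O)C3CCCC3N(C3CCCCC3)C1=O)N2`, differs from compound 2 by cyclohexyl in place of (5-fluoropyridin-2-yl)methyl on an amide-type nitrogen in a ring. No step beyond the scatter is expected in this assay. Compound 4 is therefore expected at 40000 nM (range 15000 nM to 100000 nM), a step that the limit leaves unreadable from compound 2 to compound 4, most likely again reported only as a limit.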

Compound 4, half-maximal cytotoxic concentration: > 10000 nM
Compound 4: a limit, no number; the forecaster's own chance of this, stated with the estimate: 75%; the middle value is on the limit's open side.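

For the compounds shown here, compound 2 and compound 4 both give only limits in this assay, so no step between them can be read. The compounds shown leave open where the half-maximal cytotoxic concentration of any of them actually lies.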